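The source may hold more compounds than are shown below. What is called first, only, known or untested is meant among the compounds shown, and "the series" means these compounds.

Compound 1 `S=c1oc(-c2ccc3c(c2)OCCO3)nn1CNc1ccccc1`: 5140 nM in a functional assay, with a stated time of 6 min; a higher number here means a weaker inhibitor, a lower number a stronger inhibitor
Compound 2 `S=c1oc(-c2ccc3c(c2)OCCO3)nn1CNC1CCCCC1`: 18400 nM
Compound 3 `S=c1oc(-c2ccc3c(c2)OCCO3)nn1CNc1cc(Cl)ccc1Cl`: 5420 nM

For the measured compounds named here, compound 3 stands second highest of these three numbers; compound 1 lies within the scatter of it, and the only step beyond the scatter that touches it is a 3.4-fold lower number from compound 2 to compound 3 (0.53 log units; beyond the scatter). The unmeasured compound 4 `Cc1ccc(NCn2nc(-c3ccc4c(c3)OCCO4)oc2=S)cc1` differs from compound 3 in one place: 4-methylphenyl in place of 2,5-dichlorophenyl on an amine nitrogen. Going by the values given here, one measured step bears on this, an exchange of one six-membered aromatic ring for another at the same amine nitrogen: a 1.1-fold higher number from compound 1 to compound 3 (0.02 log units; within the scatter), a change within the scatter. A similar aryl-for-aryl exchange is therefore expected to give a step no larger than the scatter, a 1.1-fold lower number from compound 3 to compound 4 (0.04 log units; within the scatter). For compound 4 the estimated value in this assay is 5000 nM, expected to fall between 2000 nM and 13000 nM.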

Compound 4, half-maximal inhibitory concentration: 5700 nM
Compound 4: middle estimate off by 1.1-fold (0.06 log units), on the low side; low and high end bracket the measured number.
By their numbers in this assay, from the lowest: compounds 1, 3 and 4 (each within the scatter of the next); then compound 2.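

In this assay, adding methyl to the phenyl ring on the amine nitrogen gives no step beyond the scatter (a 1.1-fold higher number from compound 1 to compound 4 (0.04 log units; within the scatter)), and neither does 4-methylphenyl in place of 2,5-dichlorophenyl (a 1.1-fold higher number from compound 3 to compound 4 (0.02 log units; within the scatter)), so these three aryl groups cannot be told apart here. A third aryl compound now gives a lower number than the cyclohexyl compound (a 3.2-fold lower number from compound 2 to compound 4 (0.51 log units; beyond the scatter)). No measurement on hand explains these steps. Still open, from the compounds shown here alone, is whether a pyridine ring, or a phenyl ring carrying a carboxylic acid or an amine, would shift the number at this nitrogen.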